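From fluoro to dimethylamino: expecting little change

This account rests on a few compounds, and the source may have more. Where it says the series, first, only, none or still open, it means among the compounds named here.

Of the compounds shown here, three sharing one core have been tested in a functional assay on HT-29 cells (Homo sapiens) for inhibition; a lower number here means a stronger inhibitor of growth, a higher number a weaker inhibitor of growth. There, compound 1 (`NS(=O)(=O)c1ccc(/C=C/c2ccc(O)c(O)c2)cc1`) gives 35400 nM, compound 2 (`NS(=O)(=O)c1ccc(/C=C/c2ccc(F)cc2)cc1`) gives 29400 nM and compound 3 (`NS(=O)(=O)c1ccc(/C=C/c2cccc(O)c2)cc1`) gives 43300 nM. Compound 2 stands within the scatter of both compound 1 and compound 3, so these values cannot be ranked.

The step of interest leads from compound 2 to compound 4 (`CN(C)c1ccc(/C=C/c2ccc(S(N)(=O)=O)cc2)cc1`). It puts dimethylamino in place of fluoro on an aromatic carbon, para to a large group (dimethylamino in place of fluoro on an aromatic carbon). Among the measured compounds shown here, none of the three tested compounds carries dimethylamino, so the data offer no direct precedent for this group.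

For the measured compounds named here, one measured step bears on the change, and only loosely: hydrogen in place of hydroxy on an aromatic carbon gives a 1.2-fold higher number from compound 1 to compound 3 (0.09 log units; within the scatter). Compound 1, compound 2 and compound 3 also carry different groups, yet their values all lie within the scatter of one another, and none of the three goes against this. A shift beyond the scatter is therefore not expected in either direction, and the expected step is a 1.1-fold lower number from compound 2 to compound 4 (0.02 log units; within the scatter). For compound 4 the estimated value in this assay is 28000 nM, with an expected range from 10000 nM to 60000 nM.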

Compound 4, concentration for 50% growth inhibition: 30800 nM
Beside the measured number, compound 4's estimate is 1.1-fold (0.04 log units) below it; the measured number falls inside the stated range.
By their numbers in this assay, from the lowest: compounds 2, 4, 1 and 3 (each within the scatter of the next).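

In this assay, the exchange of fluoro for dimethylamino, para to a large group, gives a 1.0-fold higher number from compound 2 to compound 4 (0.02 log units; within the scatter). Among the compounds shown here, this is the first direct reading for dimethylamino: although it brings three heavy atoms in place of one, and a hydrogen-bond acceptor that fluoro does not have in the counts used here, the step stays within the scatter at this position. No measurement is available to explain this outcome.

What the compounds shown leave open is whether any group at this place would move the number beyond the scatter, since the four compounds, ranked by value, each lie within the scatter of the next; a carboxylic acid, a primary amine or a longer alkyl chain would test this. They also leave open whether the exchange of fluoro for dimethylamino would read the same way on a different core.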